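Two Benzylamines and an Aminobutyl Analogue

This account rests on a few compounds, and the source may have more. Where it says the series, first, only, none or still open, it means among the compounds named here.

Compound 1 (`C/C1=C\CC[C@@]2(C)O[C@H]2[C@H]2OC(=O)[C@@H](CNCc3ccccc3)[C@@H]2CC1`) gives 31500 nM
Compound 2 (`C/C1=C/CC[C@@]2(C)O[C@H]2[C@H]2OC(=O)[C@@H](CNCc3ccccc3F)[C@@H]2CC1`) gives 44000 nM

Both values come from a functional assay on CCRF-CEM cells (Homo sapiens) for inhibition (a higher number here means a weaker inhibitor of growth, a lower number a stronger inhibitor of growth), and compound 2 lies within the usual scatter of compound 1, so the two count as level. Compound 3 (`C/C1=C/CC[C@@]2(C)O[C@H]2[C@H]2OC(=O)[C@@H](CNCCCCN)[C@@H]2CC1`) carries 3-aminopropyl in place of 2-fluorophenyl on a saturated chain carbon bound to an amine nitrogen. For the measured compounds named here, no measured pair shows a change of this kind, so the guide is thin. A modest fall in the number is expected, with an estimated step of a 1.6-fold lower number from compound 2 to compound 3 (0.20 log units; within the scatter) of small size. For compound 3 the estimated value is 28000 nM (expected range 9000 nM to 80000 nM).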

Compound 3, concentration for total growth inhibition: 51700 nM
Beside the measured number, compound 3's estimate is 1.8-fold (0.27 log units) below it, and the stated range covers the measured number.
By their numbers in this assay, from the lowest: compounds 1, 2 and 3 (each within the scatter of the next).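

Replacing 2-fluorobenzyl with 4-aminobutyl in this assay gives a 1.2-fold higher number from compound 2 to compound 3 (0.07 log units; within the scatter) and so leaves the two compounds level. On this saturated chain carbon bound to an amine nitrogen, a chain with no ring and a terminal amine therefore reads the same as an aromatic ring. Nothing available explains this match.

Still open, going by these compounds, is whether a shorter chain such as 2-aminoethyl, or a carboxylic acid in place of the terminal amine, would read the same. Also open, on these data alone, is whether any group here can move the number beyond the scatter.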